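Turning One Ring Carbon Over in a Weak Cortex Binder

The compounds below may be only part of what the source reports. "The series", "measured", "known", "first", "only" and "open" are said of these compounds alone.

Two compounds have numbers in an assay on membranes from Cerebral cortex for displacement of a labelled ligand from Neuronal acetylcholine receptor; alpha4/beta2 (Rattus norvegicus), with a stated time of 5 min; a lower number here means a stronger inhibitor, a higher number a weaker inhibitor. Compound 1, `CN1CCC[C@H]1[C@@H]1COc2ccc([N+](=O)[O-])cc2O1`, carries a nitro group and gives 14000 nM. Compound 2, `CC(=O)Nc1ccc2c(c1)O[C@@H]([C@@H]1CCCN1C)CO2`, carries an acetylamino group instead and gives 46000 nM. Of these two numbers compound 2 holds the higher one, and the gap to compound 1 lies beyond the usual scatter, so compound 2 is the weaker binder of the pair.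

Compound 3, `CC(=O)Nc1ccc2c(c1)O[C@H]([C@@H]1CCCN1C)CO2`, keeps every atom and bond of compound 2. the two compounds have the same atoms and bonds and differ only in configuration as drawn: 1 of 2 stereo elements differ; a stereocentre at a saturated ring carbon is drawn S in compound 2 and R in compound 3 Nothing leaves and nothing enters; only the arrangement around that one ring carbon is turned over.

Going by the values given here, no pair of such close neighbours has been measured here, so the size and direction of this kind of step are not known from the data. Turning a stereocentre can move a number either way, or leave it within the scatter. For compound 3 in this assay the estimate is 30000 nM, within a range from 8000 nM to 100000 nM. The step this estimate means, a 1.5-fold lower number from compound 2 to compound 3 (0.19 log units; within the scatter), is expected to be modest, with no firm direction.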

Compound 3, inhibition constant: 6500 nM
Compound 3: the middle estimate sits 4.6-fold (0.66 log units) above what was measured; the measured number lies below the stated range.
By their numbers in this assay, from the lowest: compound 3; then compound 1; then compound 2.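

In this assay, the configuration at this one ring carbon clearly counts: turning it over from S to R gives the largest step seen so far (a 7.1-fold lower number from compound 2 to compound 3 (0.85 log units; beyond the scatter)). With the R arrangement, acetamido in place of nitro on an aromatic carbon gives a smaller step (a 2.2-fold lower number from compound 1 to compound 3 (0.33 log units; beyond the scatter)), which leaves compound 3 with the lowest number of the three, and both of its steps lie beyond the scatter. The larger step can be pinned on that ring carbon alone, because nothing else separates the two compounds: the fact that compounds 2 and 3 differ only in the configuration as drawn

The compounds shown leave open whether turning the same ring carbon over would shift the number as far in a nitro compound, and what turning the other stereocentre would do, since each of these changes would need a partner that is not among these compounds. They also leave open whether an amine or a carboxylic acid on that aromatic carbon would give a lower number than acetamido, and why the R arrangement reads lower is not told by these numbers.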